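The compounds below may be only part of what the source reports. "The series", "measured", "known", "first", "only" and "open" are said of these compounds alone.

Measured so far:

Compound 1 `CC(C)c1cccc(C(C)C)c1NC(=O)NCCC(c1ccccc1)c1ccccc1` — in an assay on microsomes from intestine for inhibition of acyl-CoA:cholesterol acyltransferase (Oryctolagus cuniculus) (on this read-out higher numbers stand for weaker inhibition and lower numbers for stronger inhibition), compound 1 gives 140 nM.
Compound 2 `CC(C)c1cccc(C(C)C)c1NC(=O)NC1CCCc2ccccc21` — in this assay compound 2 gives 850 nM.
Compound 3 `COc1cccc(NC(=O)NCC2(c3ccccc3)CCCCC2)c1` — in this assay compound 3 gives 2500 nM.

Among these three numbers compound 3 stands highest, and its gaps to compound 2 and to compound 1 both lie beyond the scatter. No single change between measured compounds has been worked out here. Compound 4 `O=C(NCC1(c2ccccc2)CCCCC1)Nc1cc(Cl)ccc1Cl` differs from compound 3 in one place: 2,5-dichlorophenyl in place of 3-methoxyphenyl on an amide-type nitrogen. For the measured compounds named here, no measured pair shows what this kind of change does in this assay, so the expectation rests on the change itself. A modest move toward a lower number is expected, possibly within the scatter. Compound 4 is estimated at 900 nM, with a range from 250 nM to 4000 nM, which would mean an expected step of a 2.8-fold lower number from compound 3 to compound 4 (0.44 log units; beyond the scatter).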

Compound 4, half-maximal inhibitory concentration: 2700 nM
For compound 4 the middle estimate is 3.0-fold (0.48 log units) below the measured one; the measured number falls inside the stated range.
By their numbers in this assay, from the lowest: compound 1; then compound 2; then compounds 3 and 4 (each within the scatter of the next).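

In this assay, 2,5-dichlorophenyl in place of 3-methoxyphenyl on the amide-type nitrogen gives a 1.1-fold higher number from compound 3 to compound 4 (0.03 log units; within the scatter), so the two groups cannot be told apart at this position. The exchange swaps an oxygen-bearing group with a hydrogen-bond acceptor for a chlorine-bearing group without one, at the same heavy-atom count, and the number stays within the scatter. Nothing available offers an explanation for this result.
From the compounds shown here alone, whether a pyridine ring or a phenyl carrying a carboxylic acid on this nitrogen would shift the number remains open. So does whether these two groups would also match on another core.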